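The source may report more compounds than this note shows. Statements on the series, on what has been measured and on what is new or still open speak of the compounds shown alone.

Compound 1 `O=C1Nc2ccccc2/C1=C1/Cc2ccccc2C1=O` and compound 2 `O=C1Nc2ccc(Br)cc2/C1=C1/Cc2ccccc2C1=O` share one core, while compound 3 `O=C1NC(=S)N/C1=C1\C(=O)Nc2ccccc21` rests on another; how the two cores differ is not broken down here. In a functional assay on MCF7 cells (Homo sapiens) for antiproliferative activity, read by MTT assay, with a stated time of 72 h (on this read-out lower numbers stand for stronger inhibition and higher numbers for weaker inhibition), compound 1 gives 70200 nM, compound 2 gives 65200 nM, and compound 3 gives 87800 nM. The change bromo in place of hydrogen on an aromatic carbon gave a 1.1-fold lower number from compound 1 to compound 2 (0.03 log units; within the scatter). Compound 4 `O=C1NC(=S)N/C1=C1\C(=O)Nc2c(Br)cccc21` is not yet measured; it arises from compound 3 through (bromo in place of hydrogen on an aromatic carbon), the same kind of change, although here the bromo sits ortho to a fused ring and meta to a fused ring, whereas in compound 2 it sits meta to a fused ring and para to a fused ring. Compound 4 is expected to show a step of a 1.1-fold lower number from compound 3 to compound 4 (0.04 log units; within the scatter) in this assay, because the step of a 1.1-fold lower number from compound 1 to compound 2 (0.03 log units; within the scatter) stayed within the scatter. The estimate for compound 4 in this assay is 80000 nM, between 40000 nM and 160000 nM.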

Compound 4, half-maximal inhibitory concentration: 51000 nM
Compound 4: middle estimate off by 1.6-fold (0.20 log units), on the high side; low and high end bracket the measured number.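

In this assay the bromo in place of hydrogen on an aromatic carbon gave a 1.7-fold lower number from compound 3 to compound 4 (0.24 log units; within the scatter) on the second core, and the two steps agree: the same change on two cores in this assay, a 1.1-fold lower number (0.03 log units; within the scatter) from compound 1 to compound 2 and a 1.7-fold lower number (0.24 log units; within the scatter) from compound 3 to compound 4, 1.6-fold (0.20 log units) apart, within the scatter of two such steps. On these two cores, then, the change carries over in the sense that neither step can be told from the scatter. Within the data shown here, this does not show that the bromo has a real effect on either core, and with only two pairs, and the bromo at a different place on each core, it shows no general rule for the series.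

The compounds shown leave open whether an amine, a carboxylic acid or a longer chain in place of the bromo would shift the number beyond the scatter. They also leave open what the bromo would do on the core of compound 3 at the place it holds in compound 2.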